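The source may report more compounds than this note shows. Statements on the series, on what has been measured and on what is new or still open speak of the compounds shown alone.

Measured compounds:
Compound 1 `CCc1ccc(NC(=O)c2cccc(/C=C3\CC(=O)N(c4ccccc4)C3=O)c2)cc1` gives > 100000 nM in an ADME assay on NCM460 cells (Homo sapiens) for cytotoxicity, read by MTT assay, with a stated time of 72 h (on this read-out higher numbers stand for weaker inhibition and lower numbers for stronger inhibition), which is a limit of the assay.
Compound 2 `Cc1ccc(N2C(=O)C/C(=C\c3cccc(C(=O)Nc4cccc(F)c4)c3)C2=O)cc1` gives > 100000 nM in this assay, which is a limit.
Compound 3 `CCOc1ccc(NC(=O)c2cccc(/C=C3\CC(=O)N(Cc4ccccc4)C3=O)c2)cc1` gives > 100000 nM in this assay, which is a limit.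

Compound 1 therefore stands where every measured value stands, at the limit of > 100000 nM in this assay, at which 3 of the 3 values shown sit. Compound 4 `O=C(Nc1ccc(F)cc1)c1cccc(/C=C2\CC(=O)N(c3ccccc3)C2=O)c1` differs from compound 1 by fluoro in place of ethyl on an aromatic carbon. Going by the values given here, no step between measured compounds is available, so the data give no size for this change; the expectation is for no step beyond the usual scatter in this assay, with the reading again sitting at the limit. Compound 4 is accordingly expected at 150000 nM, within a range from 50000 nM to 500000 nM. This amounts to an expected step that the limit leaves unreadable from compound 1 to compound 4, not beyond the scatter.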

Compound 4, half-maximal inhibitory concentration: > 100000 nM
Compound 4: a limit, no number (the forecaster's own chance of this, stated with the estimate: 85%); the middle value is on the limit's open side.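

In this assay compound 1 and compound 4 both give a limit and not a number, so no step can be read between them. In this assay the compounds shown leave open at what concentration any of them would reach half-maximal inhibition.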